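Swapping the amine substituent on a shared xanthine-like core

The source may hold more compounds than are shown below. What is called first, only, known or untested is meant among the compounds shown, and "the series" means these compounds.

Measured so far:
compound 1 `CCCn1c(=O)[nH]c2nc(-c3ccc(S(=O)(=O)N4CCN(c5ccc(C)cc5)CC4)cc3)[nH]c2c1=O` — > 1000 nM
compound 2 `CCCn1c(=O)[nH]c2nc(-c3ccc(S(=O)(=O)N4CCN(Cc5ccc(Br)cc5)CC4)cc3)[nH]c2c1=O` — > 1000 nM

In an assay on CHO cells for displacement of a labelled ligand from adenosine receptor A3 (Homo sapiens), read by scintillation counting, with a stated time of 45 min, in the presence of a further agent that is not named here (on this read-out higher numbers stand for weaker inhibition and lower numbers for stronger inhibition), compound 1 gives only a limit, > 1000 nM. In this assay compound 2 likewise gives only a limit, > 1000 nM. The step that the two limits leave unreadable from compound 1 to compound 2 cannot be sized, because both values sit at the limit of > 1000 nM in this assay, at which 2 of the 2 values shown sit. Compound 3 `CCCn1c(=O)[nH]c2nc(-c3ccc(S(=O)(=O)N4CCN(c5ccccc5Cl)CC4)cc3)[nH]c2c1=O` differs from compound 2 by 2-chlorophenyl in place of 4-bromobenzyl on an amine nitrogen in a ring. For the measured compounds named here, no measured step gives a readable size for such a change, so no direction can be expected beyond the scatter. The step from compound 2 to compound 3 is estimated at a step that the limit leaves unreadable from compound 2 to compound 3. Compound 3 is expected to give 3000 nM in this assay, within 1000 nM to 20000 nM.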

Compound 3, inhibition constant: > 1000 nM
Compound 3 gave a limit, no number (the forecaster's own chance of this, stated with the estimate: 80%); the middle value lies beyond the limit too.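

No step between compound 1, compound 2 and compound 3 can be read in this assay, because all three give only a limit: the limit of > 1000 nM in this assay, at which 3 of the 3 values shown sit.

On these data alone, how the 4-methylphenyl, 4-bromobenzyl and 2-chlorophenyl groups rank against one another stays open.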